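Series notes: amine replacement at the shared core of compound 1

A few compounds are considered here, and "the series" means these few. Any claim that something is new, unique, unknown or untested is made for them only; others in the source may bear on it.

Measured compounds:
compound 1 `Cc1ccc2nc(N3CCNC(C)C3)nc(NCc3ccc(C(=O)NC4CCN(Cc5ccc(F)cc5)CC4)cc3)c2c1`: 2000 nM
compound 2 `Cc1ccc2nc(N(C)C)nc(NCc3ccc(C(=O)Nc4ccc(Cl)nc4)cc3)c2c1`: 1300 nM

In a functional assay on HCT-116 cells (Homo sapiens) for inhibition, read by luminescence and resazurin assay, with a stated time of 3 days (on this read-out lower numbers stand for stronger inhibition and higher numbers for weaker inhibition), compound 1 gives 2000 nM. In this assay compound 2 gives 1300 nM. Of the two numbers, that of compound 1 is the higher, but the gap to compound 2 lies within the scatter of repeated measurements, so the two compounds are not separated by these data. Going by the values given here, no step between measured compounds is available.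

Compound 3 `CCCNc1nc(NCc2ccc(C(=O)NC3CCN(Cc4ccc(F)cc4)CC3)cc2)c2cc(C)ccc2n1` is not yet measured. It differs from compound 1 in one place: propylamino in place of 3-methylpiperazin-1-yl on an aromatic carbon

Among the compounds with values here, the data give no measured step for this kind of change, so the expectation for compound 3 rests only on the two numbers at hand. A step of little size is expected, in either direction, not beyond the scatter: a 1.1-fold lower number from compound 1 to compound 3 (0.05 log units; within the scatter). For compound 3 in this assay the estimate is 1800 nM, within the range 600 nM to 5500 nM.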

Compound 3, half-maximal inhibitory concentration: 1600 nM
The estimate for compound 3 lay 1.1-fold (0.05 log units) above the measured number; the range from low to high includes it.
By their numbers in this assay, from the lowest: compounds 2, 3 and 1 (each within the scatter of the next).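

In this assay, the series now has its first one-place step at this position, and it reads a 1.3-fold lower number from compound 1 to compound 3 (0.10 log units; within the scatter). Compound 1 and compound 3 are therefore not separated by these data, even though propylamino has no ring and 3-methylpiperazin-1-yl has a six-membered non-aromatic ring with 2 hetero atoms. So, for this one pair, the ring on this aromatic carbon between two ring nitrogen atoms is not needed to keep the number within the scatter, and no measurement at hand bears on the reason for this.

Open, going by these compounds, is whether a morpholine, a longer chain such as hexylamino, or a chain ending in a carboxylic acid would also stay within the scatter of compound 1. A single step also leaves open whether the same replacement would read alike with a different amide group on the shared core.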